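Swapping the Methylphenyl for a Nitrophenyl on the Sulfonyl

The source may report more compounds than this note shows. Statements on the series, on what has been measured and on what is new or still open speak of the compounds shown alone.

Of the compounds shown here, three sharing one core have been measured in a functional assay (Cavia porcellus) with sulfonylurea receptors; K-ATP channels (Homo sapiens) as the target; a higher number here means a weaker inhibitor, a lower number a stronger inhibitor. Compound 1 `CC(O)(C(=O)Nc1ccc(S(=O)(=O)c2ccc(F)cc2)cc1)C(F)(F)F` gives 8600 nM. Compound 2 `COc1ccccc1S(=O)(=O)c1ccc(NC(=O)C(C)(O)C(F)(F)F)cc1` gives 1600 nM, and compound 3 `Cc1cccc(S(=O)(=O)c2ccc(NC(=O)C(C)(O)C(F)(F)F)cc2)c1` gives 2200 nM. Compound 3 thus holds the second highest of the three numbers: the gap a 1.4-fold higher number from compound 2 to compound 3 (0.14 log units; within the scatter) lies within the scatter, whereas a 3.9-fold lower number from compound 1 to compound 3 (0.59 log units; beyond the scatter) is a clear drop. Compound 4 `CC(O)(C(=O)Nc1ccc(S(=O)(=O)c2ccc([N+](=O)[O-])cc2)cc1)C(F)(F)F` arises from compound 3 through the change (4-nitrophenyl in place of 3-methylphenyl on a sulfonyl sulfur). Within the data shown here, no measured step shows this exact exchange. The nearest guide is that the 4-fluorophenyl of compound 1 gave the highest number, as both a 5.4-fold lower number from compound 1 to compound 2 (0.73 log units; beyond the scatter) and a 3.9-fold lower number from compound 1 to compound 3 (0.59 log units; beyond the scatter) run to lower numbers once that group is replaced, and the 4-nitrophenyl of compound 4 resembles the 4-fluorophenyl of compound 1 more than the 3-methylphenyl of compound 3. Compound 4 is therefore expected to move back towards a higher number, by roughly a 2.3-fold higher number from compound 3 to compound 4 (0.36 log units; beyond the scatter), with wide uncertainty. The estimate for compound 4 in this assay is 5000 nM, ranging from 1500 nM to 16000 nM.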

Compound 4, half-maximal inhibitory concentration: > 30000 nM
Compound 4: only a limit was reported; the forecaster's own chance of this, stated with the estimate: 5%; middle value at least 6.0-fold (0.77 log units) away from the limit.
By their numbers in this assay, from the lowest: compounds 2 and 3 (each within the scatter of the next); then compound 1. At a limit, above all of these: compound 4.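

In this assay compound 4 reaches only a limit, not a number: the limit of > 30000 nM in this assay, at which 1 of the 4 values shown sits. Even so, the exchange of 3-methylphenyl for 4-nitrophenyl on the sulfonyl sulfur gives an at least 13-fold higher number from compound 3 to compound 4 (1.13 log units; beyond the scatter), and the exchange of 2-methoxyphenyl for the same group gives an at least 18-fold higher number from compound 2 to compound 4 (1.27 log units; beyond the scatter), whereas the earlier changes at this place were only modest. Compared with the closest relative, nitro in place of fluoro on an aromatic carbon still gives an at least 3.4-fold higher number from compound 1 to compound 4 (0.54 log units; beyond the scatter), so a single exchange on that ring can push the number past anything the first three compounds showed.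

As far as these compounds go, the true size of these three steps stays open, since each rests on a limit. Also open, from the compounds shown here alone, is how an amine or a nitrile in place of the nitro on that aromatic carbon would read.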